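This account rests on a few compounds, and the source may have more. Where it says the series, first, only, none or still open, it means among the compounds named here.

Working notes on the biaryl series

Three compounds of the series have been run in a toxicity assay on MT4 cells (Homo sapiens) for cytotoxicity, read by MTT assay; a higher number here means that more compound is tolerated, a lower number that less compound is tolerated. Compound 1 `Cc1cc(-c2cccc(F)c2)cc(C)c1Oc1cc(N)nc(Nc2ccc(C#N)cc2)n1` gives 24700 nM. Compound 2 `Cc1cc(-c2ccc(F)cc2)cc(C)c1Oc1cc(N)nc(Nc2ccc(C#N)cc2)n1` gives 23100 nM. Compound 3 `Cc1cc(-c2cccc(Cl)c2)cc(C)c1Oc1cc(N)nc(Nc2ccc(C#N)cc2)n1` gives 22300 nM. The three numbers lie within the scatter of one another, so none of the compounds can be called better or worse tolerated than another. Compound 2 sits among them: a 1.1-fold lower number from compound 1 to compound 2 (0.03 log units; within the scatter) and a 1.0-fold lower number from compound 2 to compound 3 (0.02 log units; within the scatter) are both within the scatter, as is a 1.1-fold lower number from compound 1 to compound 3 (0.04 log units; within the scatter).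

The next compound, compound 4 `Cc1cc(-c2ccc(C#N)c(F)c2)cc(C)c1Oc1cc(N)nc(Nc2ccc(C#N)cc2)n1`, differs from compound 2 in one place: 4-cyano-3-fluorophenyl in place of 4-fluorophenyl on an aromatic carbon. The measured steps speak to changes on this same ring, but all three concern a single halogen at one position, and none of them moved this assay beyond the scatter. Among the compounds with values here, no measured step introduces a nitrile on this ring, nor a second substituent on it, so the present change is without direct precedent here.

Given that every change on this ring so far left this assay flat, compound 4 is expected to land near compound 2, with a 1.1-fold lower number from compound 2 to compound 4 (0.02 log units; within the scatter) expected to stay within the scatter. The estimate for compound 4 in this assay is 22000 nM, with a range from 10000 nM to 50000 nM.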

Compound 4, half-maximal cytotoxic concentration: 5000 nM
Estimate against measurement, compound 4: 4.4-fold (0.64 log units) above, and the stated range ends above it.
By their numbers in this assay, from the lowest: compound 4; then compounds 3, 2 and 1 (each within the scatter of the next).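

Halogen changes on this ring left the number flat, but the nitrile does not: in this assay, a 4.9-fold lower number from compound 1 to compound 4 (0.69 log units; beyond the scatter), with cyano in place of hydrogen on an aromatic carbon as the single change. The wider replacements agree, with a 4.6-fold lower number from compound 2 to compound 4 (0.66 log units; beyond the scatter) and a 4.5-fold lower number from compound 3 to compound 4 (0.65 log units; beyond the scatter), so this ring is not indifferent to every substituent, and among the four compounds only compound 4 stands apart from the others. No measurement at hand bears on what lies behind this lower tolerated concentration.

The nitrile appears here only together with the fluoro on the same ring, so the compounds shown leave open whether the nitrile would give a step of this size on a ring with no halogen, or whether the pairing of the two substituents matters. Also open, as far as these compounds go, is whether other groups at this place, such as an amine, a carboxylic acid or a methoxy group, would leave the number flat like the halogens or lower it as the nitrile does.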